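Branching the aryl alkyl chain: compound 3 to compound 4

A few compounds are considered here, and "the series" means these few. Any claim that something is new, unique, unknown or untested is made for them only; others in the source may bear on it.

Compound 1 `Cc1cc(Oc2ccccc2OCCn2ccc(=O)[nH]c2=O)c(C)c2cc(C#N)ccc12` reaches only the assay limit in a toxicity assay on MT2 cells (Homo sapiens) for cytotoxicity, read by MTT assay (on this read-out lower numbers stand for higher toxicity in this test and higher numbers for lower toxicity in this test), giving > 100000 nM. Compound 2 `CCc1cc(Oc2ccccc2OCCn2ccc(=O)[nH]c2=O)c(C)c2cc(C#N)ccc12` gives 12000 nM in this assay, and compound 3 `CCCc1cc(Oc2ccccc2OCCn2ccc(=O)[nH]c2=O)c(C)c2cc(C#N)ccc12` gives 15000 nM, the highest of the two numbers, with compound 2 nearest. Replacing hydrogen with methyl gave an at least 8.3-fold lower number from compound 1 to compound 2 (0.92 log units; beyond the scatter), and with ethyl an at least 6.6-fold lower number from compound 1 to compound 3 (0.82 log units; beyond the scatter), whereas lengthening the chain by one carbon gave only a 1.3-fold higher number from compound 2 to compound 3 (0.10 log units; within the scatter). Compound 4 `Cc1c(Oc2ccccc2OCCn2ccc(=O)[nH]c2=O)cc(C(C)C)c2ccc(C#N)cc12` changes compound 3 by isopropyl in place of propyl on an aromatic carbon. Within the data shown here, the only comparison of two alkyl groups of like size, that between compound 2 and compound 3, stayed within the scatter, so no step beyond the scatter is expected in this assay. Compound 4 is expected to give 15000 nM, within 6000 nM to 40000 nM. That estimate means no change at the digits printed from compound 3 to compound 4 (within the scatter).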

Compound 4, half-maximal cytotoxic concentration: 9000 nM
Compound 4: the middle estimate sits 1.7-fold (0.22 log units) above what was measured, and the stated range covers the measured number.
By their numbers in this assay, from the lowest: compounds 4, 2 and 3 (each within the scatter of the next). At a limit, above all of these: compound 1.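

Isopropyl in place of propyl on this aromatic carbon gives a 1.7-fold lower number from compound 3 to compound 4 (0.22 log units; within the scatter) in this assay and methyl on the carbon of the ethyl group bound to the aromatic carbon gives a 1.3-fold lower number from compound 2 to compound 4 (0.12 log units; within the scatter) so branching here adds no step beyond the scatter. Isopropyl in place of methyl gives an at least 11-fold lower number from compound 1 to compound 4 (1.04 log units; beyond the scatter) as the only new step beyond the scatter. The value of compound 1 is a limit, so this step is one too: the limit of > 100000 nM in this assay, at which 1 of the 4 values shown sits.

As far as these compounds go, whether a tert-butyl group or a longer chain such as butyl stays level with compound 2, compound 3 and compound 4 remains open. So does the effect of an amine or a carboxylic acid at this position.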